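Hydrazone aryl swap to a guaiacol-type ring in cytotoxicity

The source may report more compounds than this note shows. Statements on the series, on what has been measured and on what is new or still open speak of the compounds shown alone.

Going by the values given here, compound 3 `CN(C)CCn1cnnc1-c1cc(Oc2ccc(NC(=O)N/N=C/c3ccccc3O[N+](=O)[O-])cc2F)ccn1` gives 1270 nM in a functional assay on NCI-H460 cells (Homo sapiens) for cytotoxicity, read by MTT assay, with a stated time of 72 h (on this read-out lower numbers stand for stronger inhibition and higher numbers for weaker inhibition), the lowest of the three numbers known so far. Compound 1 `CN(C)CCn1cnnc1-c1cc(Oc2ccc(NC(=O)N/N=C/c3ccc(O)c(O)c3)cc2F)ccn1` gives 1930 nM and compound 2 `CN(C)CCn1cnnc1-c1cc(Oc2ccc(NC(=O)N/N=C/c3cc(Br)c(O)c(Br)c3)cc2F)ccn1` gives 3760 nM; the steps are a 1.5-fold lower number from compound 1 to compound 3 (0.18 log units; within the scatter) and a 3.0-fold lower number from compound 2 to compound 3 (0.47 log units; beyond the scatter). Compound 4 `COc1cc(/C=N/NC(=O)Nc2ccc(Oc3ccnc(-c4nncn4CCN(C)C)c3)c(F)c2)ccc1O` differs from compound 3 by 4-hydroxy-3-methoxyphenyl in place of 2-(nitrooxy)phenyl on a carbon with a double bond to nitrogen. The step that bears most on this is a 1.5-fold lower number from compound 1 to compound 3 (0.18 log units; within the scatter), since the entering group, like that of compound 1, carries a hydroxyl; the move from compound 1 to compound 2 was a 1.9-fold higher number from compound 1 to compound 2 (0.29 log units; within the scatter). The step from compound 3 to compound 4 is therefore expected to stay within the scatter, a 1.3-fold higher number from compound 3 to compound 4 (0.13 log units; within the scatter). Compound 4 is estimated at 1700 nM, within a range from 800 nM to 3600 nM.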

Compound 4, half-maximal inhibitory concentration: 57 nM
Estimate against measurement, compound 4: 30-fold (1.47 log units) above, and the stated range ends above it.
By their numbers in this assay, from the lowest: compound 4; then compounds 3, 1 and 2 (each within the scatter of the next, the first and the last beyond it).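

The three earlier aryl groups spanned only a modest range in this assay, whereas 4-hydroxy-3-methoxyphenyl at this place gives a 22-fold lower number from compound 3 to compound 4 (1.35 log units; beyond the scatter) and a 66-fold lower number from compound 2 to compound 4 (1.82 log units; beyond the scatter). Going by these compounds alone, the clearest reading is the single change of methyl in place of hydrogen on an oxygen on an aromatic ring, a 34-fold lower number from compound 1 to compound 4 (1.53 log units; beyond the scatter), which shows that one small edit to this ring can carry a large step. Nothing available here explains why the step is so large.

From the compounds shown here alone, it remains open whether the methyl itself matters, or whether an ethyl on that oxygen would serve as well. Going by these compounds, it is also open whether an amine in place of the remaining hydroxyl would keep the step.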